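The compounds below may be only part of what the source reports. "The series", "measured", "known", "first", "only" and "open" are said of these compounds alone.

Measured compounds in a functional assay on HL-60 cells (Homo sapiens) for inhibition, read by MTT assay, with a stated time of 72 h, tested at 50 uM; a higher number here means more inhibition of growth at the concentration tested, a lower number less inhibition of growth:
compound 1 `C=CCc1ccc(OCc2cn(-c3ccccc3CO)nn2)c(O)c1` — 47.1%
compound 2 `C=CCc1ccc(OCc2cn(-c3cccc(C#N)c3)nn2)c(O)c1` — 30.9%
compound 3 `C=CCc1ccc(OCc2cn(-c3ccc(Br)cc3)nn2)c(O)c1` — 25.6%

Compound 2 stands second highest of the three numbers. Its nearest neighbour is compound 3, and the step of a number 5.3 percentage points lower from compound 2 to compound 3 (within the scatter) lies within the scatter; the step of a number 16.2 percentage points lower from compound 1 to compound 2 (beyond the scatter) lies beyond the scatter, as does a number 21.5 percentage points lower from compound 1 to compound 3 (beyond the scatter). All three steps exchange the whole aryl group on the aromatic nitrogen of the shared core, and only the two that remove the 2-(hydroxymethyl)phenyl group move the number beyond the scatter.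

Compound 4 `C=CCc1ccc(OCc2cn(-c3cccc([N+](=O)[O-])c3)nn2)c(O)c1` differs from compound 2 in one place: nitro in place of cyano on an aromatic carbon. For the measured compounds named here, no measured step exchanges cyano for nitro, so nothing bears on this change directly. The closest guide is the step from compound 2 to compound 3, which swapped one substituted phenyl for another and stayed within the scatter. On that basis no step beyond the scatter is expected in this assay for this change, in either direction.

Compound 4 is therefore estimated to give 31% in this assay, with a range from 18% to 44%. The expected step is a number 0.1 percentage points higher from compound 2 to compound 4 (within the scatter), within the scatter.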

Compound 4, percent growth inhibition at one concentration: 65.5%
Beside the measured number, compound 4's estimate is 34.5 percentage points below it, and the stated range ends below it.
By their numbers in this assay, from the lowest: compounds 3 and 2 (each within the scatter of the next); then compound 1; then compound 4.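

For the compounds shown here, exchanging cyano for nitro on an aromatic carbon, meta to a large group, gives in this assay a number 34.6 percentage points higher from compound 2 to compound 4 (beyond the scatter) and is the only large step so far, whereas the earlier steps beyond the scatter were modest and each exchanged the whole aryl group. A change confined to one substituent on the phenyl group can therefore move the number further than those exchanges did, so this aromatic carbon is a sensitive place in the series and the two groups there are not interchangeable. Nothing measured here accounts for the size of this step.

On these data alone, it remains open whether the higher number is specific to nitro or would also appear with other groups on the same aromatic carbon, such as an amine, a carboxylic acid or a methyl ester. The compounds shown also leave open whether the step seen at this single tested concentration would hold across a range of concentrations, and whether nitro would give a similar step on other aryl groups of the series, such as the 2-(hydroxymethyl)phenyl of compound 1.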